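Series notes: one trifluoromethyl removed, expected read-out

The compounds below may be only part of what the source reports. "The series", "measured", "known", "first", "only" and "open" are said of these compounds alone.

compound 1 `O=C(Nc1cccc(-n2cc(-c3ccncc3)c(-c3cc(O)cc(Cl)c3)n2)c1)Nc1ccc(Cl)c(Cl)c1`: 108%
compound 2 `COc1cc(Cl)cc(-c2nn(-c3cccc(NC(=O)Nc4cc(C(F)(F)F)cc(C(F)(F)F)c4)c3)cc2-c2ccncc2)c1`: 104%

In a functional assay on DU-145 cells (Homo sapiens) for inhibition, read by sulforhodamine B assay, with a stated time of 48 h, tested at 0.01 uM (a higher number here means a weaker effect of the compound at the concentration tested, a lower number a stronger effect), compound 1 gives 108%. In this assay compound 2 gives 104%. Compound 2 holds the lower of the two numbers, yet the gap to compound 1 lies within the scatter, so the pair shows no order; neither compound has a clear effect at this concentration.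

Compound 3 `COc1cc(Cl)cc(-c2nn(-c3cccc(NC(=O)Nc4cccc(C(F)(F)F)c4)c3)cc2-c2ccncc2)c1` differs from compound 2 by hydrogen in place of trifluoromethyl on an aromatic carbon. Among the measured compounds shown here, no measured step covers this change. Since compound 2 gives 104%, compound 3 is expected near it, with an expected step of a number 2 percentage points lower from compound 2 to compound 3 (within the scatter), none beyond the scatter. Compound 3 is estimated at 102%, within 90% to 114%.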

Compound 3, a percentage reported as activity, at one concentration (the size of the read-out at that concentration, not a potency): 101%
Beside the measured number, compound 3's estimate is 1 percentage points above it; the measured number falls inside the stated range.
By their numbers in this assay, from the lowest: compounds 3, 2 and 1 (each within the scatter of the next).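

In this assay, among the compounds shown here, hydrogen in place of trifluoromethyl on this aromatic carbon gives a number 3 percentage points lower from compound 2 to compound 3 (within the scatter) and provides the first step between compounds differing in one place. Neither compound has a clear effect at this concentration, so the step does not show whether the trifluoromethyl group at this position matters for the read-out. No supporting data bear on the result.

Going by these compounds, it remains open whether an amine or a carboxylic acid on this carbon would give a number beyond the scatter. On these data alone, it also remains open whether compound 2 and compound 3 would separate at higher concentrations.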